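This account rests on a few compounds, and the source may have more. Where it says the series, first, only, none or still open, it means among the compounds named here.

Clearance series, measured in an ADME assay on the whole organism (plasma, strain CD) for pharmacokinetics, with Rattus norvegicus as the target; on this read-out higher numbers stand for fast clearance and lower numbers for slow clearance:
- compound 1 `Cn1c(=O)c(C(=O)NCCO)c(O)c2ncc(Cc3ccc(F)cc3)cc21`: 3.2 mL/min/kg
- compound 2 `C[C@@H](CO)CNC(=O)c1c(O)c2ncc(Cc3ccc(F)cc3)cc2n(C)c1=O`: "not determined" (no result reported)
- compound 3 `COCCNC(=O)c1c(O)c2ncc(Cc3ccc(F)cc3)cc2[nH]c1=O`: "not determined" (no result reported)

For the measured compounds named here, only one compound has a number so far. In this assay compound 3 stands at "not determined" (no result reported), so it offers no single number to work from, and compound 2 is in the same position at "not determined" (no result reported). The next compound to read is compound 4 `COCCNC(=O)c1c(O)c2ncc(Cc3ccc(F)cc3)cc2n(C)c1=O`, which departs from its parent as follows: methyl in place of hydrogen on an aromatic nitrogen. In words, this is methyl in place of hydrogen on an aromatic nitrogen.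

Going by the values given here, no measured pair shows what this change does to clearance, so the data give no size or direction for it. No step beyond the usual scatter is expected, and the range is kept wide. Among the compounds with values here, the expectation rests on compound 1 at 3.2 mL/min/kg, the only number available. For compound 4 the expected clearance is an estimated 5 mL/min/kg, within a range of 2 mL/min/kg to 13 mL/min/kg.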

Compound 4, clearance: 11.8 mL/min/kg
Estimate against measurement, compound 4: 2.4-fold (0.37 log units) below, within the range that was stated.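

In this assay, methyl in place of hydrogen on an oxygen on a saturated carbon, at the end of the amide chain, gives a 3.7-fold higher number from compound 1 to compound 4 (0.57 log units; beyond the scatter). For the compounds shown here, this is the first readable step, and it shows that clearance in this pair responds to a single methyl at the chain end, while the shared core stays the same. Nothing in the data explains the rise, which rests on this one pair.

On these data alone, the other step cannot be read, as compound 3 has no single number, so what methyl on the aromatic nitrogen does to clearance remains open. Also open, as far as these compounds go, is how this assay would respond if the chain ended in an amine or a carboxylic acid, or if a longer chain carried the terminal hydroxy group.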